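Changing one aromatic group on compound 2

A few compounds are considered here, and "the series" means these few. Any claim that something is new, unique, unknown or untested is made for them only; others in the source may bear on it.

Measured in a functional assay on HeLa cells (Homo sapiens) for antiproliferative activity, read by spectrophotometry, with a stated time of 2 days; a lower number here means a stronger inhibitor of growth, a higher number a weaker inhibitor of growth:
- compound 1 `CN(c1cccc2c1CN(c1nc(Nc3ccc(C(F)(F)F)cc3)ncc1C(F)(F)F)C2)S(C)(=O)=O`: > 30000 nM (a limit of the assay, not a number)
- compound 2 `COc1cc(Nc2ncc(C(F)(F)F)c(N3Cc4cccc(N(C)S(C)(=O)=O)c4C3)n2)cc(OC)c1`: 7000 nM

For the measured compounds named here, compound 2 holds the only true number so far, 7000 nM. Compound 3 `Cc1ccc(Nc2ncc(C(F)(F)F)c(N3Cc4cccc(N(C)S(C)(=O)=O)c4C3)n2)c(C)c1` differs from compound 2 in one place: 2,4-dimethylphenyl in place of 3,5-dimethoxyphenyl on a nitrogen on an aromatic ring. Going by the values given here, one measured step bears on this place: an at least 4.2-fold lower number from compound 1 to compound 2 (0.63 log units; beyond the scatter), which is beyond the scatter. Among the compounds with values here, with only this modest step as a guide, a change of similar or smaller size is expected in this assay, towards a higher number. The expected change is a 1.7-fold higher number from compound 2 to compound 3 (0.23 log units; within the scatter). Compound 3 is estimated at 12000 nM, with a range from 4000 nM to 30000 nM.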

Compound 3, concentration for 50% growth inhibition: 10600 nM
Compound 3: middle estimate off by 1.1-fold (0.05 log units), on the high side; measured number inside the range.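

In this assay, 2,4-dimethylphenyl in place of 3,5-dimethoxyphenyl gives a 1.5-fold higher number from compound 2 to compound 3 (0.18 log units; within the scatter), so on this nitrogen a ring without hydrogen-bond acceptors does not differ measurably from one with them. Against 4-(trifluoromethyl)phenyl, the same group gives an at least 2.8-fold lower number from compound 1 to compound 3 (0.45 log units; beyond the scatter), so 3,5-dimethoxyphenyl is no longer the only group shown to clear that comparison. Compound 1 carries a limit of the assay, not a number: the limit of > 30000 nM in this assay, at which 1 of the 3 values shown sits.

Going by these compounds, what stays open is how an aromatic ring bearing an amine or a carboxylic acid would behave at this place. On these data alone, whether any group here can bring the number far lower also remains unknown.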